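Trimming a side chain from compound 3 to compound 4

The compounds below may be only part of what the source reports. "The series", "measured", "known", "first", "only" and "open" are said of these compounds alone.

Three compounds have been measured in an ADME assay on microsomes from liver (Mus musculus) for metabolic stability, read by LC-MS, with a stated time of 4 h, tested at 1 uM (a higher number here means faster removal of the compound, a lower number slower removal), so far
compound 1 `CCOc1cc(NC(=O)NCc2cc(C)c(-c3cn(C)nc3C)cn2)cc(Cl)n1` gives 700 mL/min/kg
compound 2 `COCCOc1cc(NC(=O)NCc2cc(C)c(-c3cn(C)nc3C(F)(F)F)nn2)cc(Cl)n1` gives 317 mL/min/kg
compound 3 `Cc1cc(CNC(=O)Nc2cc(OCC(O)CO)nc(C(F)(F)F)c2)nnc1-c1cn(C)nc1C(F)(F)F` gives < 76.7 mL/min/kg, which is a limit and not a number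

Microsomes are fragments of liver cells that carry enzymes able to break down foreign compounds, so a test of this kind gives an early view of how quickly a compound may be cleared. Compound 1 and compound 2 both return numbers. Compound 3 stands alone at the limit of < 76.7 mL/min/kg in this assay, at which 1 of the 3 values shown sits, and offers no exact number to build on.

Compound 4 `Cc1cc(CNC(=O)Nc2cc(OCCO)nc(C(F)(F)F)c2)nnc1-c1cn(C)nc1C(F)(F)F` differs from compound 3 in one place (hydrogen in place of hydroxymethyl on a saturated chain carbon bound to an oxygen on a saturated carbon and a saturated chain carbon). Hydrogen takes the place of hydroxymethyl on a saturated chain carbon bound to an oxygen on a saturated carbon and a saturated chain carbon, so 2,3-dihydroxypropoxy becomes 2-hydroxyethoxy. For the measured compounds named here, no two measured compounds differ in only one place, so no measured step can serve as a guide here. The expected change is small and upward in this assay, and the estimated at least 1.1-fold higher number from compound 3 to compound 4 (0.06 log units; that floor lies within the scatter) may stay within the usual scatter. For compound 4 the estimated clearance is 90 mL/min/kg (expected range 50 mL/min/kg to 190 mL/min/kg).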

Compound 4, clearance: 102 mL/min/kg
Beside the measured number, compound 4's estimate is 1.1-fold (0.05 log units) below it, and the stated range covers the measured number.
By their numbers in this assay, from the lowest: compound 4; then compound 2; then compound 1. At a limit, below all of these: compound 3.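

Hydrogen in place of hydroxymethyl turns 2,3-dihydroxypropoxy into 2-hydroxyethoxy, and this gives the only step here between compounds that differ in one place: in this assay it reads as an at least 1.3-fold higher number from compound 3 to compound 4 (0.12 log units; that floor lies within the scatter). With the shorter chain, compound 4 gives 102 mL/min/kg, so this side chain now has an exact number to build on, and removing the hydroxymethyl leaves clearance in the same low part of the values shown rather than near the numbers of the other compounds. The true size of the step remains unknown because compound 3 is held at a limit and not a number: the limit of < 76.7 mL/min/kg in this assay, at which 1 of the 4 values shown sits.

The compounds shown leave open how clearance responds when the hydroxyl of 2-hydroxyethoxy itself is replaced, for example by a methoxy group, an amine or a carboxylic acid, or when a longer chain ending in a hydroxyl stands in its place. Compound 1 and compound 2 carry other side chains but differ from compound 4 in more than one place, so they cannot show whether the same change would behave alike on a different core.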